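This account rests on a few compounds, and the source may have more. Where it says the series, first, only, none or still open, it means among the compounds named here.

Measured so far in an assay on IMR-32 cells for displacement of a labelled ligand from corticotropin-releasing factor receptor 1 (Homo sapiens), read by scintillation counting, with a stated time of 2 h; a higher number here means a weaker inhibitor, a lower number a stronger inhibitor:
compound 1 `CCC(CC)Nc1nc(OC)c(-c2ccc(Cl)cc2Cl)nc1C` — 14.4 nM
compound 2 `CCc1nc(N(CC2CC2)CC2CC2)c(CC)nc1-c1ccc(Cl)cc1Cl` — 26 nM

Of the two numbers, that of compound 2 is the higher; compound 1 lies within the scatter of it, so the two cannot be separated on this evidence. Compound 3 `CCc1nc(-c2ccc(Cl)cc2Cl)c(CC)nc1NC(C)CN(C)C` differs from compound 2 in one place: (1-((dimethylamino)methyl)ethyl)amino in place of bis(cyclopropylmethyl)amino on an aromatic carbon. Going by the values given here, no measured pair shows the effect of such an exchange. The number for compound 3 is expected to rise modestly, a step of a 2.3-fold higher number from compound 2 to compound 3 (0.36 log units; beyond the scatter). The estimate for compound 3 in this assay is 60 nM, with a range from 15 nM to 250 nM.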

Compound 3, inhibition constant: 489 nM
The estimate for compound 3 lay 8.2-fold (0.91 log units) below the measured number; the measured number lies above the stated range.
By their numbers in this assay, from the lowest: compounds 1 and 2 (each within the scatter of the next); then compound 3.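

In this assay the exchange of bis(cyclopropylmethyl)amino for (1-((dimethylamino)methyl)ethyl)amino gives a 19-fold higher number from compound 2 to compound 3 (1.27 log units; beyond the scatter) and so shows that this position does not tolerate every amino group alike. The exchange removes both three-membered rings and adds a hydrogen-bond donor and a second nitrogen in a single step. No available evidence ties the loss to any one of these differences.

As far as these compounds go, it remains open how a dipropylamino group, with no ring and no second nitrogen, would fare here. A morpholine at the same carbon would test a second nitrogen's replacement by oxygen within a ring.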